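A few compounds are considered here, and "the series" means these few. Any claim that something is new, unique, unknown or untested is made for them only; others in the source may bear on it.

Of the compounds shown here, three on the shared core have been read so far in a functional assay on HeLa cells (Homo sapiens) for inhibition, read by CCK-8 assay, with a stated time of 48 h (on this read-out higher numbers stand for weaker inhibition and lower numbers for stronger inhibition), as the only test. Compound 2 `COc1cc(-c2ccnc3cc(-c4cn(CO)c5ccccc45)nn23)cc(OC)c1OC` gives 103 nM as the lowest of the two numerical values, while compound 1 `COc1cc(-c2ccnc3cc(-c4ccc(F)cc4)nn23)cc(OC)c1OC` gives 5840 nM as the higher one, a gap well beyond the usual scatter. Compound 3 `COc1cc(-c2cc3nccc(-c4c[nH]c5ccccc45)n3n2)cc(OC)c1OC` gives > 10000 nM as its reading, and this is a limit of the assay, not a number.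

Next comes compound 4 `COc1cc(-c2ccnc3cc(-c4c[nH]c5ccccc45)nn23)cc(OC)c1OC`, which differs from compound 2 in one place: hydrogen in place of hydroxymethyl on an aromatic nitrogen of a five-membered aromatic ring with 1 nitrogen, with hydrogen in place of hydroxymethyl on an aromatic nitrogen as the counted change. Among the compounds with values here, no measured pair isolates this change, so its size can only be estimated. With compound 2 at 103 nM as the anchor, no step beyond the scatter is expected in this assay as the central case, though the range stays wider on the weaker side. The expected move is a 1.5-fold higher number from compound 2 to compound 4 (0.16 log units; within the scatter) as a central estimate. For compound 4 the estimated value is 150 nM with an expected range from 30 nM to 800 nM in this test.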

Compound 4, half-maximal inhibitory concentration: 195 nM
Compound 4: middle estimate off by 1.3-fold (0.11 log units), on the low side, and the stated range covers the measured number.
By their numbers in this assay, from the lowest: compounds 2 and 4 (each within the scatter of the next); then compound 1. At a limit, above all of these: compound 3.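

In this assay, hydrogen in place of hydroxymethyl on the aromatic nitrogen gives a 1.9-fold higher number from compound 2 to compound 4 (0.28 log units; within the scatter), so at this position the reading does not depend on which of these two groups is present. 1H-indol-3-yl in place of 4-fluorophenyl on an aromatic carbon gives a 30-fold lower number from compound 1 to compound 4 (1.48 log units; beyond the scatter), a large step, and it appears with hydrogen on the nitrogen, so it does not require the hydroxymethyl. Nothing measured here bears on the cause of either step.

Open, going by these compounds, is whether this nitrogen also accepts a methyl, an acetyl or a longer chain ending in an amine or a carboxylic acid. Also open, on these data alone, is how a chloro or methoxy substituent elsewhere on the 1H-indol-3-yl group would read.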